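The compounds below may be only part of what the source reports. "The series", "measured", "known", "first", "only" and "open" are said of these compounds alone.

Compound 1 `COc1ccc([C@@H]2[C@H](Oc3ccccc3)C(=O)N2c2cc(OC)c(OC)c(OC)c2)cc1OC` was tested in a functional assay on MCF7 cells (Homo sapiens) for antiproliferative activity, read by MTT assay, with stated times of 24 h and 72 h (on this read-out lower numbers stand for stronger inhibition and higher numbers for weaker inhibition), where compound 1 gives 26000 nM. Among the three compounds measured so far, compound 1 stands second highest: compound 2 `COc1cc(N2C(=O)[C@@H](Oc3ccccc3)[C@H]2c2ccc(SC)cc2)cc(OC)c1OC` gives 7700 nM in this assay, while compound 3 `COc1cc([N+](=O)[O-])c([C@@H]2[C@H](Oc3ccccc3)C(=O)N2c2cc(OC)c(OC)c(OC)c2)cc1O` gives 59000 nM. The two steps away from compound 1 are a 3.4-fold lower number from compound 1 to compound 2 (0.53 log units; beyond the scatter) and a 2.3-fold higher number from compound 1 to compound 3 (0.36 log units; beyond the scatter); between the other pair, a 7.7-fold higher number from compound 2 to compound 3 (0.88 log units; beyond the scatter).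

Compound 4 `COc1cc(N2C(=O)[C@@H](Oc3ccccc3)[C@H]2c2cc(N)c(OC)c(O)c2)cc(OC)c1OC` has not yet been measured in this assay. It differs from compound 1 in one place: a group of 10 heavy atoms (7 carbon, 1 nitrogen, 2 oxygen; one six-membered aromatic ring of carbon only) in place of a group of 10 heavy atoms (8 carbon, 2 oxygen; one six-membered aromatic ring of carbon only), on a saturated ring carbon. Like the group found in compound 3, the entering group contains nitrogen as well as oxygen and brings hydrogen-bond donors, and the only comparable measured step, a 2.3-fold higher number from compound 1 to compound 3 (0.36 log units; beyond the scatter), moved the number modestly upward. Within the data shown here, no measured compound carries the entering group itself, so the expectation rests on that single step and is loose. The expected step is a 1.5-fold higher number from compound 1 to compound 4 (0.16 log units; within the scatter). Compound 4 is estimated at 38000 nM, with a range from 12000 nM to 110000 nM.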

Compound 4, half-maximal inhibitory concentration: 8800 nM
Compound 4: middle estimate off by 4.3-fold (0.64 log units), on the high side; the whole stated range lies above it.
By their numbers in this assay, from the lowest: compounds 2 and 4 (each within the scatter of the next); then compound 1; then compound 3.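

The result shows that a group containing nitrogen and bringing hydrogen-bond donors can lower the number at this saturated ring carbon, which compound 3 alone had not suggested: in this assay the change gives a 3.0-fold lower number from compound 1 to compound 4 (0.47 log units; beyond the scatter), and the two nitrogen-containing groups are separated by a 6.7-fold lower number from compound 3 to compound 4 (0.83 log units; beyond the scatter). The 4-(methylsulfanyl)phenyl group and the group in compound 4 differ in their atoms, yet they give values within the scatter of each other, with a 1.1-fold higher number from compound 2 to compound 4 (0.06 log units; within the scatter). No evidence is available to explain these differences.

The compounds shown leave open whether a phenyl ring carrying only an amine or only a hydroxyl would give a similar number. From the compounds shown here alone, all four compounds keep the phenoxy group, and the effect of a carboxylic acid or a longer chain in its place remains open.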